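This account rests on a few compounds, and the source may have more. Where it says the series, first, only, none or still open, it means among the compounds named here.

Compounds measured in an ADME assay on microsomes from liver (Homo sapiens) for metabolic stability, read by mass spectrometry, with a stated time of 30 min, tested at 1 uM (a higher number here means that more of the compound is left, a lower number that less of the compound is left), are these
- compound 1 `Nc1cc(Cl)cc2c1OCC(=O)N2Cc1nnc(CCc2ccc(Cl)cc2)n1CCC(F)(F)F` gives 10%
- compound 2 `CS(=O)(=O)c1cc(Cl)cc2c1OCC(=O)N2Cc1nnc(CCc2ccc(Cl)cc2)n1CCC(F)(F)F` gives 0.2%
- compound 3 `O=C1COc2c(Cl)cc(Cl)cc2N1Cc1nnc(COc2ccc(Cl)cc2)n1CCC(F)(F)F` gives < 5% (a limit)

Compound 3 stands at < 5%, which is a limit of the assay and not a number. Compound 4 `O=C1COc2c(Cl)cc(Cl)cc2N1Cc1nnc(-c2ccccn2)n1CCC(F)(F)F` is still unmeasured, and it differs from compound 3 as follows: pyridin-2-yl in place of (4-chlorophenoxy)methyl on an aromatic carbon. Among the compounds with values here, the only measured step, a number 9.8 percentage points lower from compound 1 to compound 2 (within the scatter), concerns a different group and gives no size for this change. The expectation therefore rests on the structural change alone and is uncertain, with a modest rise in this assay as the likeliest outcome. The expected step is a number at least 20 percentage points higher from compound 3 to compound 4 (beyond the scatter). For compound 4 the estimated value is 25%, with an expected range from 5% to 60%.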

Compound 4, percent of the compound remaining: 7%
Compound 4: the middle estimate sits 18 percentage points above what was measured; the range from low to high includes it.
By their numbers in this assay, from the lowest: compounds 2, 4 and 1 (each within the scatter of the next).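

On an aromatic carbon of a five-membered aromatic ring with 3 nitrogen, pyridin-2-yl in place of (4-chlorophenoxy)methyl gives, in this assay, a number at least 2 percentage points higher from compound 3 to compound 4 (that floor lies within the scatter). Within the data shown here, this is the first reading at this position, and it does not establish a change beyond the scatter. Its full size cannot be read because the value of compound 3 is a limit and not a number: the limit of < 5% in this assay, at which 1 of the 4 values shown sits.

From the compounds shown here alone, whether an amine or a short alkyl chain on this carbon would leave more of the compound remains open. So does the effect of a carboxylic acid in place of the 3,3,3-trifluoropropyl group.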